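The source may report more compounds than this note shows. Statements on the series, on what has been measured and on what is new or still open speak of the compounds shown alone.

Measured compounds in an ADME assay on microsomes from liver (Homo sapiens) for metabolic stability; on this read-out higher numbers stand for fast clearance and lower numbers for slow clearance:
- compound 1 `CC(C)(C(=O)O)c1nn(Cc2cn3cc(OCC4CC4)c(Cl)cc3n2)c2ccccc2c1=O`: compound 1 gives 21.7 mL/min/kg
- compound 2 `C[C@H](C(=O)O)n1nc(Cn2cc3cc(OCC4CC4)c(Cl)cc3n2)c2ccccc2c1=O`: compound 2 gives 20 mL/min/kg
- compound 3 `O=C(O)Cn1nc(Cc2cn3cc(OCC4CC4)c(Cl)cc3n2)c2ccccc2c1=O`: compound 3 gives only a limit of the assay, < 16.7 mL/min/kg

Among the two numbers reported, compound 1 has the higher one in this assay, but compound 2 sits within the usual scatter of it, so the two cannot be ranked against each other. For compound 3 the assay reports no number, only (the limit of < 16.7 mL/min/kg in this assay, at which 1 of the 3 values shown sits), and that is all that can be said of it. For the measured compounds named here, no pair of these three differs in a single place, so no measured step is available for the series.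

The next compound, compound 4 `CC(C(=O)O)c1nn(Cc2cn3cc(OCC4CC4)c(Cl)cc3n2)c2ccccc2c1=O`, is the analogue of compound 1 with hydrogen in place of methyl on a saturated chain carbon bound to an aromatic carbon, a carbonyl carbon and a saturated chain carbon. The shared core, the side chain bearing the chloro and cyclopropylmethoxy groups, and the carboxylic acid are kept; only the degree of branching at the carbon carrying the acid changes. The three measured values all lie close together, and nothing here separates a branched from a less branched acid carbon beyond the scatter. The step of a 1.2-fold lower number from compound 1 to compound 4 (0.08 log units; within the scatter) is therefore expected to be small, if anything toward slower clearance, and within the scatter. Compound 4 is expected to give 18 mL/min/kg in this assay, with a likely range from 11 mL/min/kg to 28 mL/min/kg.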

Compound 4, clearance: 35 mL/min/kg
Compound 4: middle estimate off by 1.9-fold (0.29 log units), on the low side, and the stated range ends below it.
By their numbers in this assay, from the lowest: compounds 2, 1 and 4 (each within the scatter of the next). At a limit, below all of these: compound 3.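

Working notes on the series: in this assay, hydrogen in place of methyl on a saturated chain carbon bound to an aromatic carbon, a carbonyl carbon and a saturated chain carbon gives a 1.6-fold higher number from compound 1 to compound 4 (0.21 log units; within the scatter) and so provides the first measured step at a single place in this series. This change, from 1-carboxy-1-methylethyl to 1-carboxyethyl, therefore cannot be separated from the usual variation between repeated measurements, and the read-out gives no ground for ranking compound 1 against compound 4, even though the printed numbers of the pair are further apart than those of compound 1 and compound 2. No measurement shown gives a cause for this step.

From the compounds shown here alone, it remains open whether ethyl, fluorine or a cyclopropyl ring built on the same saturated chain carbon would give a step beyond the scatter, and whether an amide or a tetrazole in place of the carboxylic acid would do so. Compound 3 offers no number to settle this, and its reading is only a limit of the assay: the limit of < 16.7 mL/min/kg in this assay, at which 1 of the 4 values shown sits.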